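Thioether variation and cytotoxicity in the shared core

A few compounds are considered here, and "the series" means these few. Any claim that something is new, unique, unknown or untested is made for them only; others in the source may bear on it.

The series shares one core, seen in compound 1 `C[C@@H]1CCN(c2cc(-c3ccccc3)nc3ncnn23)C[C@@H]1N(C)c1ncnc2[nH]ccc12`, compound 2 `Cc1cc(N2CC[C@@H](C)[C@@H](N(C)c3ncnc4[nH]ccc34)C2)n2nc(SCc3cc(Cl)ccc3Cl)nc2n1` and compound 3 `C=CCSc1nc2nc(C)cc(N3CC[C@@H](C)[C@@H](N(C)c4ncnc5[nH]ccc45)C3)n2n1`, and differs mainly at the sulfur-bound chain. In a toxicity assay on GES1 cells (Homo sapiens) for inhibition, read by MTT assay, with a stated time of 72 h (on this read-out lower numbers stand for stronger inhibition and higher numbers for weaker inhibition), compound 1 gives > 100000 nM, a limit of the assay rather than a number. Compound 2 gives 87500 nM in this assay. Compound 3 gives > 100000 nM in this assay, again a limit and not a number, so compound 3 sits at the limit of > 100000 nM in this assay, at which 2 of the 3 values shown sit. For the measured compounds named here, the only measured step bearing on the change, an at least 1.1-fold higher number from compound 2 to compound 3 (0.05 log units; that floor lies within the scatter), lies within the scatter. Compound 4 `Cc1cc(N2CC[C@@H](C)[C@@H](N(C)c3ncnc4[nH]ccc34)C2)n2nc(SCc3ccc([N+](=O)[O-])cc3)nc2n1` differs from compound 3 by 4-nitrophenyl in place of vinyl on a saturated chain carbon bound to a sulfur. No step beyond the scatter is expected, so compound 4 is estimated at 95000 nM, spanning 50000 nM to 200000 nM. For compound 4 this amounts to an expected step of an at least 1.0-fold lower number from compound 3 to compound 4 (0.02 log units; that floor lies within the scatter).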

Compound 4, half-maximal inhibitory concentration: 36600 nM
Compound 4: the middle estimate sits 2.6-fold (0.41 log units) above what was measured; measured number below the stated range.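

In this assay the place on a saturated chain carbon bound to a sulfur now gives a change beyond the scatter: 4-nitrophenyl brings an at least 2.7-fold lower number from compound 3 to compound 4 (0.43 log units; beyond the scatter) and also a 2.4-fold lower number from compound 2 to compound 4 (0.38 log units; beyond the scatter) in the same direction. Vinyl and 2,5-dichlorophenyl had not separated, so this place is not indifferent to the group it carries. The step from vinyl remains a floor, since one of its ends is a limit: (the limit of > 100000 nM in this assay, at which 2 of the 4 values shown sit).

On these data alone, the effect of an amine or a carboxylic acid at this place remains open. So does whether a longer chain would keep the lower number of compound 4.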